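Rigid aryl linker in place of alkyl chain: stilbene hydroxamates

This account rests on a few compounds, and the source may have more. Where it says the series, first, only, none or still open, it means among the compounds named here.

Measured compounds:
compound 1, `COc1cc(/C=C/c2ccc(OCCCC(=O)NO)cc2)cc(OC)c1`, 5200 nM
compound 2, `COc1cc(/C=C/c2ccc(OCCCCCC(=O)NO)cc2)cc(OC)c1`, 4100 nM
compound 3, `COc1cc(/C=C/c2ccc(OCCCCCCC(=O)NO)cc2)cc(OC)c1`, 1070 nM

All three compounds were tested in a functional assay on HCT-116 cells (Homo sapiens) for cytotoxicity, read by MTT assay, with a stated time of 48 h; on this read-out higher numbers stand for weaker inhibition and lower numbers for stronger inhibition. Compound 1 gives the highest number of the three; compound 2 is nearest, a 1.3-fold lower number from compound 1 to compound 2 (0.10 log units; within the scatter), and compound 3 is furthest, a 4.9-fold lower number from compound 1 to compound 3 (0.69 log units; beyond the scatter). Between the two longer chains, a 3.8-fold lower number from compound 2 to compound 3 (0.58 log units; beyond the scatter).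

Compound 4, `COc1cc(/C=C/c2ccc(OCc3ccccc3C(=O)NO)cc2)cc(OC)c1`, has not been measured. Compared with compound 1, (2-(hydroxycarbamoyl)phenyl in place of 2-(hydroxycarbamoyl)ethyl on a saturated chain carbon bound to an oxygen on an aromatic ring). The measured steps all concern lengthening of the chain at this place; none replaces the chain with a ring. Lengthening gave a modest lowering, seen from compound 1 to compound 3, and a step within the scatter from compound 1 to compound 2. For the measured compounds named here, no measured step covers the aromatic linker, so the direction is uncertain; compound 4 is expected to give a number somewhat lower than compound 1, with a step of a 2.1-fold lower number from compound 1 to compound 4 (0.32 log units; beyond the scatter). The estimate for compound 4 is 2500 nM, with a range from 600 nM to 10000 nM.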

Compound 4, half-maximal inhibitory concentration: 13900 nM
Compound 4: the middle estimate sits 5.6-fold (0.75 log units) below what was measured, outside the stated range (above it).
By their numbers in this assay, from the lowest: compound 3; then compounds 2 and 1 (each within the scatter of the next); then compound 4.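

In this assay, for the compounds shown here, 2-(hydroxycarbamoyl)phenyl at this place, on a saturated chain carbon bound to an oxygen on an aromatic ring, moved the number upward, with a 2.7-fold higher number from compound 1 to compound 4 (0.43 log units; beyond the scatter), whereas no lengthening of the chain among the earlier compounds had raised it. The gap widens against the longer chains, with a 3.4-fold higher number from compound 2 to compound 4 (0.53 log units; beyond the scatter) and a 13-fold higher number from compound 3 to compound 4 (1.11 log units; beyond the scatter), so compound 4 gives the highest number of the four and the aromatic linker does not match any of the saturated chains here. Nothing available here accounts for this rise.

The compounds shown leave open whether a chain longer than 5-(hydroxycarbamoyl)pentyl would lower the number further. They also leave open how a carboxylic acid in place of the hydroxycarbamoyl on the phenyl ring would compare with compound 4.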